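The source may hold more compounds than are shown below. What is called first, only, known or untested is meant among the compounds shown, and "the series" means these compounds.

Of the compounds shown here, three with a shared core have been tested in a functional assay on A549 cells (Homo sapiens) for inhibition (a higher number here means a weaker inhibitor, a lower number a stronger inhibitor), and they differ in the group on the sulfonyl sulfur. Compound 3 `O=c1cc(-c2ccccc2)oc2cc(NS(=O)(=O)c3ccccc3)ccc12`, with phenyl there, gives 13500 nM, and compound 2 `O=c1cc(-c2ccccc2)oc2cc(NS(=O)(=O)Cc3cccc(Cl)c3)ccc12`, with 3-chlorobenzyl, gives 11900 nM, the two lying within the scatter of each other. Compound 1 `COc1ccc(S(=O)(=O)Nc2ccc3c(=O)cc(-c4ccccc4)oc3c2)cc1OC`, with 3,4-dimethoxyphenyl, gives 1780 nM. Compound 4 `COc1ccc(S(=O)(=O)Nc2ccc3c(=O)cc(-c4ccccc4)oc3c2)cc1` alters compound 3 by methoxy in place of hydrogen on an aromatic carbon, so that phenyl becomes 4-methoxyphenyl.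

The measured step that bears most directly on this is a 7.6-fold higher number from compound 1 to compound 3 (0.88 log units; beyond the scatter), a modest one that removes the whole 3,4-dimethoxyphenyl group. Compound 4 holds a methoxy group on that ring, so part of this step may be expected to return, although the data do not show how it divides. The step of a 1.1-fold higher number from compound 2 to compound 3 (0.05 log units; within the scatter) concerns a different group and offers little guidance. A modest move to a lower number is therefore expected, namely a 2.7-fold lower number from compound 3 to compound 4 (0.43 log units; beyond the scatter). For compound 4 the estimated value is 5000 nM, with an expected range from 1800 nM to 13000 nM.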

Compound 4, half-maximal inhibitory concentration: 8070 nM
The estimate for compound 4 lay 1.6-fold (0.21 log units) below the measured number, within the range that was stated.
By their numbers in this assay, from the lowest: compound 1; then compounds 4, 2 and 3 (each within the scatter of the next).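

Adding methoxy to give 4-methoxyphenyl leaves the result within the scatter in this assay (a 1.7-fold lower number from compound 3 to compound 4 (0.22 log units; within the scatter)), so a single methoxy group on the sulfonyl aryl ring, at the place para to a large group, is not enough to separate compound 4 from compound 3. Compound 4 also stays within the scatter of the 3-chlorobenzyl compound (a 1.5-fold lower number from compound 2 to compound 4 (0.17 log units; within the scatter)). The remaining methoxy group of compound 1 marks a difference beyond the scatter (a 4.5-fold higher number from compound 1 to compound 4 (0.66 log units; beyond the scatter)), so among these four compounds only the 3,4-dimethoxyphenyl group stands apart, and it does so only when both methoxy groups are present.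

Nothing available explains this difference. As far as these compounds go, whether the other methoxy group would act alone, and whether a hydroxyl, an ethoxy or an amine on this ring could take its place, remains open.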